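Fluorine on the benzoyl ring: a step from compound 3

A few compounds are considered here, and "the series" means these few. Any claim that something is new, unique, unknown or untested is made for them only; others in the source may bear on it.

Measured compounds:
- Compound 1 `COc1cc(C(=O)C2Sc3nnc(-c4cc(OC)c(OC)c(OC)c4)n3NC2c2ccco2)cc(OC)c1OC` gives > 100000 nM in a functional assay on MCF7 cells (Homo sapiens) for cytotoxicity, read by MTT assay, with a stated time of 48 h; a lower number here means a stronger inhibitor, a higher number a weaker inhibitor; this value is a limit of the assay, not a number.
- Compound 2 `COc1cc(-c2nnc3n2NC(c2ccco2)C(C(=O)c2ccc(Cl)cc2)S3)cc(OC)c1OC` gives > 100000 nM in this assay; this too is a limit of the assay.
- Compound 3 `COc1cc(-c2nnc3n2NC(c2ccco2)C(C(=O)c2ccccc2)S3)cc(OC)c1OC` gives 39800 nM in this assay.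

Compound 3 is the only one of the three with a numerical result; the other two sit at a limit, as the line the limit of > 100000 nM in this assay, at which 2 of the 3 values shown sit, records. Compound 4 `COc1cc(-c2nnc3n2NC(c2ccco2)C(C(=O)c2ccc(F)c(F)c2)S3)cc(OC)c1OC` is not yet measured. It differs from compound 3 in one place: 3,4-difluorophenyl in place of phenyl on a carbonyl carbon.

Among the compounds with values here, two measured steps bear on this change. The step of an at least 2.5-fold lower number from compound 2 to compound 3 (0.40 log units; beyond the scatter) and the step of an at least 2.5-fold lower number from compound 1 to compound 3 (0.40 log units; beyond the scatter) both show that the bare phenyl on the carbonyl carbon gives a lower number than a substituted phenyl there. The step that the two limits leave unreadable from compound 1 to compound 2 cannot be read, because the limit of > 100000 nM in this assay, at which 2 of the 3 values shown sit, holds both of its compounds.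

Putting fluorines onto the phenyl of compound 3 is therefore expected to move the number in this assay upward, by an at least modest step, possibly back to the limit. The expected step is a 2.0-fold higher number from compound 3 to compound 4 (0.30 log units; within the scatter). Compound 4 is estimated at 80000 nM, within a range from 25000 nM to 250000 nM.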

Compound 4, half-maximal inhibitory concentration: 73200 nM
Compound 4: middle estimate off by 1.1-fold (0.04 log units), on the high side; the range from low to high includes it.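

In this assay the step of a 1.8-fold higher number from compound 3 to compound 4 (0.26 log units; within the scatter) shows that the 3,4-difluorophenyl on the carbonyl carbon cannot be told apart from the plain phenyl. It also shows that a substituted phenyl at this position need not end at the limit, as the 4-chlorophenyl and 3,4,5-trimethoxyphenyl groups do. The steps of an at least 1.3-fold lower number from compound 2 to compound 4 (0.13 log units; that floor lies within the scatter) and an at least 1.3-fold lower number from compound 1 to compound 4 (0.13 log units; that floor lies within the scatter) are floors only, and their true size stays unread because the other compound in each pair sits at a limit: the limit of > 100000 nM in this assay, at which 2 of the 4 values shown sit.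

The compounds shown leave open whether a single fluorine, a methyl or an amine on the benzoyl ring would give a number like that of compound 4. They also leave open what a cyclohexyl in place of the aromatic ring on the carbonyl carbon would give.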